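The source may report more compounds than this note shows. Statements on the series, on what has been measured and on what is new or still open speak of the compounds shown alone.

Measured compounds in this series:

compound 1 `CC1(C)S[C@@H]2/C(=C\C(=O)c3ccc4ccccc4c3)C(=O)N2[C@H]1C(=O)OC(c1ccccc1)c1ccccc1` — 36500 nM
compound 2 `CC1(C)[C@H](C(=O)OC(c2ccccc2)c2ccccc2)N2C(=O)/C(=C/C(=O)c3ccccc3)[C@H]2S1(=O)=O` — 17500 nM
compound 3 `CC1(C)[C@H](C(=O)OC(c2ccccc2)c2ccccc2)N2C(=O)/C(=C/C(=O)c3ccc([N+](=O)[O-])cc3)[C@H]2[S+]1[O-]` — 48200 nM

All three values come from a functional assay on A-375 cells (Homo sapiens) for cytotoxicity, read by MTT assay, with a stated time of 48 h; a higher number here means a weaker inhibitor, a lower number a stronger inhibitor. Compound 1 stands second highest of the three numbers: its nearest neighbour is compound 3, whose number is higher by an amount that stays inside the usual scatter, so no order between compound 1 and compound 3 can be read from these two values; the furthest is compound 2, whose number lies lower by an amount beyond the scatter. For the measured compounds named here, the three compounds differ from one another in more than one place, so no single-change step among them is available.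

The next compound, compound 4 `CC1(C)S[C@@H]2/C(=C\C(=O)c3ccc([N+](=O)[O-])cc3)C(=O)N2[C@H]1C(=O)OC(c1ccccc1)c1ccccc1`, is compound 1 with one change: 4-nitrophenyl in place of naphthalen-2-yl on a carbonyl carbon. The same 4-nitrophenyl carbonyl is present in compound 3, but on a different core, so nothing in the measured set isolates this exchange. Going by the values given here, with no step to go on, the expectation for this change is no movement beyond the scatter, leaning, if anywhere, toward a somewhat higher number. Compound 4 is therefore estimated at 42000 nM in this assay, with a range of 15000 nM to 110000 nM. This estimate means a step of a 1.2-fold higher number from compound 1 to compound 4 (0.06 log units; within the scatter), which is small relative to the spread already seen.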

Compound 4, half-maximal inhibitory concentration: 50300 nM
Compound 4: the middle estimate sits 1.2-fold (0.08 log units) below what was measured; the measured number falls inside the stated range.
By their numbers in this assay, from the lowest: compound 2; then compounds 1, 3 and 4 (each within the scatter of the next).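

In this assay, for the compounds shown here, replacing naphthalen-2-yl with 4-nitrophenyl on a carbonyl carbon gives a 1.4-fold higher number from compound 1 to compound 4 (0.14 log units; within the scatter), the first single-change step, and no order between the two compounds can be read from it. At this place on the core of compound 1, then, going from two six-membered aromatic rings of carbon only to one, with hydrogen-bond acceptors entering on the nitro group, does not separate the two values beyond the scatter. Nothing measured on these compounds offers an explanation for this result, and none can be assigned to either group.

One step on one core cannot show whether the same exchange would read alike on the other cores in the series, so it supports no general statement about this position. It also leaves open whether an aryl group carrying an amine or a carboxylic acid, or a longer alkyl chain on the same carbonyl carbon, would move the number in this assay beyond the scatter.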